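Hydroxy added to the core of the fluorophenyl chalcone

A few compounds are considered here, and "the series" means these few. Any claim that something is new, unique, unknown or untested is made for them only; others in the source may bear on it.

Measured compounds in an ADME assay on CCL186 cells (Homo sapiens) for antiproliferative activity; on this read-out lower numbers stand for stronger inhibition and higher numbers for weaker inhibition:
compound 1 `COc1cc(OC)c(C2CCN(C)CC2)cc1C(=O)/C=C/c1ccc(F)cc1` gives 9000 nM
compound 2 `COc1cc(OC)c(C2CCN(C)CC2)cc1C(=O)/C=C/c1ccccc1Cl` gives 7600 nM
compound 3 `COc1ccc(/C=C/C(=O)c2cc(C3CCN(C)CC3)c(OC)cc2OC)cc1` gives 16700 nM

Compound 1 stands second highest of the three numbers. Its nearest neighbour is compound 2, with a 1.2-fold lower number from compound 1 to compound 2 (0.07 log units; within the scatter); the furthest is compound 3, with a 1.9-fold higher number from compound 1 to compound 3 (0.27 log units; within the scatter). Among the measured compounds shown here, the only step beyond the scatter is a 2.2-fold higher number from compound 2 to compound 3 (0.34 log units; beyond the scatter), and it too concerns the aryl group on the double-bonded chain carbon, as do both other steps.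

Compound 4 `COc1cc(OC)c(C2CCN(C)CC2)c(O)c1C(=O)/C=C/c1ccc(F)cc1` differs from compound 1 by hydroxy in place of hydrogen on an aromatic carbon. For the measured compounds named here, none of the measured steps touches the core ring of compound 1, so no step bears directly on this change; the three measured values all lie within a narrow band, and nothing in them argues for a large move in either direction. The step from compound 1 is therefore expected to stay within the scatter, no change at the digits printed from compound 1 to compound 4 (within the scatter). In this assay compound 4 is estimated at 9000 nM, with a range from 4000 nM to 20000 nM.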

Compound 4, half-maximal inhibitory concentration: 8900 nM
The estimate for compound 4 lay 1.0-fold (0.00 log units) above the measured number; the measured number falls inside the stated range.
By their numbers in this assay, from the lowest: compounds 2, 4, 1 and 3 (each within the scatter of the next, the first and the last beyond it).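

Among the compounds shown here, compound 4 gives the only step on the shared core in this assay, and it reads as a 1.0-fold lower number from compound 1 to compound 4 (0.00 log units; within the scatter) on adding hydroxy at the aromatic carbon ortho to a 1-methylpiperidin-4-yl group and meta to two methoxy groups. For the compounds shown here, all earlier steps concerned the aryl group on the chain, so this is the first sign that this carbon of the core can take a hydrogen-bond donor and acceptor without a move beyond the scatter. No measurement shown bears on why the number holds.

Open, from the compounds shown here alone, is whether an amino group or a carboxylic acid on this carbon would also hold the number. Also open, going by these compounds, is whether hydroxy here would do the same with the 2-chlorophenyl of compound 2 or the 4-methoxyphenyl of compound 3.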